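A longer imidazole tether and its expected effect

A few compounds are considered here, and "the series" means these few. Any claim that something is new, unique, unknown or untested is made for them only; others in the source may bear on it.

This account concerns two measured compounds and one still awaiting measurement in an ADME assay on NHBE cells (Homo sapiens) for antiproliferative activity, read by MTT assay, with a stated time of 48 h; on this read-out lower numbers stand for stronger inhibition and higher numbers for weaker inhibition. Among the compounds with values here, compound 1 `C=CC(=O)Nc1cccc(Nc2nc(Nc3ccc(Cn4ccnc4)cc3OC)ncc2Cl)c1` is the first of the measured pair. In this assay compound 1 gives > 40000 nM, which is a limit of the assay rather than a number. Within the data shown here, compound 2 `C=CC(=O)Nc1cccc(Nc2nc(Nc3ccc(-n4ccnc4)cc3)ncc2[N+](=O)[O-])c1` differs from compound 1 in more than one place, so no single step between the two can be drawn. In this assay compound 2 gives > 40000 nM, again a limit and not a measured number. Both values sit at the limit of > 40000 nM in this assay, at which 2 of the 2 values shown sit, and on the numbers shown compound 2 stands at the same limit as compound 1, with nothing to set the two apart. Compound 3 `C=CC(=O)Nc1cccc(Nc2nc(Nc3ccc(OCCCn4ccnc4)cc3)ncc2[N+](=O)[O-])c1` is the compound still to be measured; its change from compound 2 is 3-(1H-imidazol-1-yl)propoxy in place of 1H-imidazol-1-yl on an aromatic carbon. Among the measured compounds shown here, no measured step is available, and the expected step is a number no higher from compound 2 to compound 3 (the limit leaves the size open), none beyond the scatter, because compound 2 already sits at the limit of > 40000 nM in this assay, at which 2 of the 2 values shown sit. Compound 3 is therefore expected to give about 40000 nM, within 15000 nM to 150000 nM, most likely again only as a limit.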

Compound 3, half-maximal inhibitory concentration: 39200 nM
Estimate against measurement, compound 3: 1.0-fold (0.01 log units) above; measured number inside the range.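

With 3-(1H-imidazol-1-yl)propoxy in place of 1H-imidazol-1-yl on this aromatic carbon, para to a large group, the read-out in this assay gives an at least 1.0-fold lower number from compound 2 to compound 3 (0.00 log units; that floor lies within the scatter). Compound 3, at 39200 nM, thus provides the only value of the three shown that is a number and not a limit, so this position accepts the longer chain ending in the same imidazole without any change beyond the scatter being shown. The true size of the step remains unfixed because compound 2 carries only a limit, as does compound 1: the limit of > 40000 nM in this assay, at which 2 of the 3 values shown sit.

What the compounds shown leave open is whether any group at this position can bring the number in this assay clearly away from that limit, for instance a morpholine or a dimethylamine in place of the imidazole at the end of the propoxy chain. Also open, as far as these compounds go, is how a shorter ethoxy chain or a longer butoxy chain carrying the same imidazole would read in this assay.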